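The source may hold more compounds than are shown below. What is called first, only, known or untested is meant among the compounds shown, and "the series" means these compounds.

Of the compounds shown here, three built on one shared core have been measured in an assay on HEK293 cells for agonist activity at Toll-like receptor 8 (Homo sapiens), read by spectrophotometry; on this read-out higher numbers stand for an effect only at larger amounts of compound and lower numbers for an effect already at smaller amounts. Compound 1 `CCCCNc1nc(N)nc(C)c1CCCn1c(C)nc2ccccc21` gives 366 nM, compound 2 `CCCCNc1nc(N)nc(C)c1CC` gives 1660 nM, and compound 3 `CCCCNc1nc(N)nc(C)c1CCCN1CCN(C(=O)OC(C)(C)C)CC1` gives 300 nM. Compound 2 therefore stands at the highest number of the three, with compound 1 and compound 3 both beyond the scatter below it. Compound 4 `CCCCNc1nc(N)nc(C)c1C` has not yet been measured in this assay. It differs from compound 2 by hydrogen in place of methyl on a saturated chain carbon bound to an aromatic carbon. Within the data shown here, no two measured compounds differ in a single place, so this step is untested. Compound 2 already sits above the longer-chain compounds 1 and 3, so a further shortening is expected to push the number upward. The expected step is a 2.1-fold higher number from compound 2 to compound 4 (0.32 log units; beyond the scatter). Compound 4 is estimated at 3500 nM, between 1200 nM and 10000 nM.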

Compound 4, half-maximal effective concentration: 3280 nM
Compound 4: the middle estimate sits 1.1-fold (0.03 log units) above what was measured; the measured number falls inside the stated range.
By their numbers in this assay, from the lowest: compounds 3 and 1 (each within the scatter of the next); then compounds 2 and 4 (each within the scatter of the next).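

In this assay, hydrogen in place of methyl on a saturated chain carbon bound to an aromatic carbon, which also reads as ethyl to methyl, gives a 2.0-fold higher number from compound 2 to compound 4 (0.30 log units; within the scatter). Among these compounds, this is the first single-place step at this position, and it leaves compound 2 and compound 4 not clearly separated on this read-out. Nothing available here accounts for this step.

The compounds shown leave open how a plain propyl chain would read at this position. They also leave open how an amine at the end of that chain would read.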